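Mirror-Image Ring Carbons and Stability in Caco-2 Cells

A few compounds are considered here, and "the series" means these few. Any claim that something is new, unique, unknown or untested is made for them only; others in the source may bear on it.

Three compounds that share one set of atoms and bonds and differ only in the configuration drawn at their stereocentres have been measured in an ADME assay on Caco-2 cells (Homo sapiens) for metabolic stability, read by HPLC, with a stated time of 12 h; a lower number here means that the compound disappears faster, a higher number that the compound lasts longer. Compound 1, `O=C(N[C@H](CO)C(=O)O)[C@@H]1C[C@@H](O)CN1`, gives > 12 h, which is a limit of the assay rather than a number. Compound 2, `O=C(N[C@H](CO)C(=O)O)[C@@H]1C[C@H](O)CN1`, also reaches the limit, > 12 h. Compound 3, `O=C(O)[C@H](CO)NC(=O)[C@@H]1C[C@@H](O)CN1`, sits at the limit as well, > 12 h. Because of the limit of > 12 h in this assay, at which 3 of the 3 values shown sit, none of the steps between these three can be read: a step that the two limits leave unreadable from compound 1 to compound 2, a step that the two limits leave unreadable from compound 1 to compound 3 and a step that the two limits leave unreadable from compound 2 to compound 3 all stay hidden behind the limit.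

Compound 4, `O=C(O)[C@@H](CO)NC(=O)[C@H]1C[C@@H](O)CN1`, has not yet been measured. It differs from compound 2 as follows: the two compounds have the same atoms and bonds and differ only in configuration as drawn: 2 of 3 stereo elements differ; a stereocentre at a saturated ring carbon is drawn S in compound 2 and R in compound 4; a stereocentre at a saturated ring carbon is drawn S in compound 2 and R in compound 4. Among the measured compounds shown here, the steps that bear on this change are those from compound 1 to compound 2 and from compound 2 to compound 3, each of which also turns a stereocentre at a saturated ring carbon; both were unreadable. No direction or size beyond the scatter can therefore be expected in this assay. Compound 4 is expected to stand at about 12 h, in the range 8 h to 24 h, most likely reported as a limit. The expected step from compound 2 to compound 4 is a number no higher from compound 2 to compound 4 (the limit leaves the size open).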

Compound 4, half-life: > 12 h
Compound 4 ended at the assay's limit (the forecaster's own chance of this, stated with the estimate: 80%); the middle value sits exactly at the limit.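

In this assay compound 4 gives > 12 h (a limit of the assay, not a number). No step linking compound 4 with compound 1, compound 2 or compound 3 can be read, for one reason: the limit of > 12 h in this assay, at which 4 of the 4 values shown sit. The compounds shown leave open how long each one actually lasts and whether its drawn configuration makes any difference.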